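The source may hold more compounds than are shown below. What is called first, only, known or untested is meant among the compounds shown, and "the series" means these compounds.

Compound 1 `Cc1nc(N2CCC(N3CCNC3=O)CC2)nc2ccc(NC(=O)/C=C/c3ccc(OC(F)(F)F)cc3)cc12` gives the lowest number of the two measured in a functional assay on CHO-K1 cells for antagonist activity at melanin-concentrating hormone receptor 1 (Homo sapiens), read by inositol phosphate accumulation, with stated times of 10 min and 45 min (a lower number here means a stronger inhibitor, a higher number a weaker inhibitor), at 31 nM. Compound 2 `Cc1nc(N2CCC(O)(C3CC3)CC2)nc2ccc(NC(=O)/C=C/c3ccc(Cl)cc3Cl)cc12` gives 575 nM in this assay, a higher number that lies well beyond the scatter from that of compound 1; the two differ in several places at once, so no single step can be read from them. Compound 3 `Cc1nc(N2CCC(N3CCCC3=O)CC2)nc2ccc(NC(=O)/C=C/c3ccc(OC(F)(F)F)cc3)cc12` differs from compound 1 only by 2-oxopyrrolidin-1-yl in place of 2-oxoimidazolidin-1-yl on a saturated ring carbon. For the measured compounds named here, no measured step covers this change, so a small shift toward a higher number is expected, possibly none beyond the scatter, as a 1.6-fold higher number from compound 1 to compound 3 (0.21 log units; within the scatter). Compound 3 is estimated at 50 nM in this assay, within 15 nM to 180 nM.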

Compound 3, half-maximal inhibitory concentration: 12 nM
Beside the measured number, compound 3's estimate is 4.2-fold (0.62 log units) above it; measured number below the stated range.
By their numbers in this assay, from the lowest: compound 3; then compound 1; then compound 2.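

In this assay, 2-oxopyrrolidin-1-yl in place of 2-oxoimidazolidin-1-yl gives a 2.6-fold lower number from compound 1 to compound 3 (0.41 log units; beyond the scatter), the first single-place step read in the series. At this saturated ring carbon, the hydrogen-bond donor counted on the leaving group is therefore not required for a low number on the core of compound 1. No measured evidence accounts for the size or direction of this step.

From the compounds shown here alone, whether a six-membered lactam, an open-chain acetamide or a primary amine at the same carbon would keep this number remains open. Going by these compounds, whether the step carries over with other groups on the cinnamide aryl ring also remains open.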